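The source may hold more compounds than are shown below. What is called first, only, known or untested is meant among the compounds shown, and "the series" means these compounds.

Measured in a functional assay on PC-3 cells (Homo sapiens) for antiproliferative activity, read by WST assay, with a stated time of 3 days; a lower number here means a stronger inhibitor, a higher number a weaker inhibitor:
Compound 1 `CCOc1c(-c2cc(OC)c(OC)c(OC)c2)oc2ccccc2c1=O`: 900 nM
Compound 2 `CCCCCOc1c(-c2cc(OC)c(OC)c(OC)c2)oc2ccccc2c1=O`: 22200 nM
Compound 3 `CCCCCCOc1c(-c2cc(OC)c(OC)c(OC)c2)oc2ccccc2c1=O`: 29200 nM

Compound 2 belongs with compound 3 at the weak end of this small set, and far from compound 1. Compound 4 `CCC(C)Oc1c(-c2cc(OC)c(OC)c(OC)c2)oc2ccccc2c1=O` has sec-butyl in place of pentyl on an oxygen on an aromatic ring.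

Going by the values given here, no measured compound carries sec-butyl, so the measured steps can only bracket this change. Two of them are large: a 25-fold higher number from compound 1 to compound 2 (1.39 log units; beyond the scatter) and a 32-fold higher number from compound 1 to compound 3 (1.51 log units; beyond the scatter). The third stays small, at a 1.3-fold higher number from compound 2 to compound 3 (0.12 log units; within the scatter). The chain of compound 1 gives much the lowest number, and sec-butyl is a smaller group than pentyl. A move part of the way back towards compound 1 therefore seems likely in this assay, with a lower number but probably not the full size of those large steps. The expected change is a 4.4-fold lower number from compound 2 to compound 4 (0.65 log units; beyond the scatter). The estimate for compound 4 is 5000 nM, with an expected range of 1200 nM to 20000 nM.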

Compound 4, half-maximal inhibitory concentration: 38600 nM
The estimate for compound 4 lay 7.7-fold (0.89 log units) below the measured number; the whole stated range lies below it.
By their numbers in this assay, from the lowest: compound 1; then compounds 2, 3 and 4 (each within the scatter of the next).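

In this assay, sec-butyl in place of pentyl on the oxygen leaves the number within the scatter (a 1.7-fold higher number from compound 2 to compound 4 (0.24 log units; within the scatter)), and the same holds against hexyl (a 1.3-fold higher number from compound 3 to compound 4 (0.12 log units; within the scatter)). A smaller group on this oxygen therefore does not by itself move the number back towards compound 1, and branching does not set compound 4 apart from the straight chains of compound 2 and compound 3. The gap to the ethyl group of compound 1 stays large (a 43-fold higher number from compound 1 to compound 4 (1.63 log units; beyond the scatter)), leaving compound 1 the strongest of the four, and no supporting data explain this result.

From the compounds shown here alone, it remains open how propyl or butyl on this oxygen would read, and so where the number rises between ethyl and the other three groups. Methyl and an ethyl chain carrying an amine are also open.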